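Pyridin-3-yl in place of the benzylic 4-fluorophenyl

The source may report more compounds than this note shows. Statements on the series, on what has been measured and on what is new or still open speak of the compounds shown alone.

Compound 1 `Fc1ccc(Cn2ccc3nc(-c4ccccc4)nc-3c2)cc1` is tested in an ADME assay on MDBK cells (Bos taurus) for cytotoxicity; a higher number here means that more compound is tolerated, a lower number that less compound is tolerated. In this assay compound 1 reaches only the limit of > 100000 nM, so its standing is known as a range, not as a point. Compound 2 `CC(C)(C)c1ccc(Cn2ccc3nc(-c4ccccc4)nc-3c2)cc1` gives 22000 nM in this assay. Going by the values given here, the single measured step is an at least 4.5-fold lower number from compound 1 to compound 2 (0.65 log units; beyond the scatter). For compound 1 the value is the limit (the limit of > 100000 nM in this assay, at which 1 of the 2 values shown sits). Compound 3 `c1ccc(-c2nc3ccn(Cc4cccnc4)cc-3n2)cc1` differs from compound 1 by pyridin-3-yl in place of 4-fluorophenyl on a saturated chain carbon bound to an aromatic nitrogen. The measured step from compound 1 to compound 2 touches the same pendant ring but alters a substituent on it rather than exchanging the ring itself, so it bears on the new change only loosely and gives no clear direction. No step beyond the scatter is therefore expected for compound 3 in this assay. Compound 3 is estimated at 100000 nM, between 40000 nM and 200000 nM, with a report sitting again at the limit the likeliest outcome. The expected step is a number no higher from compound 1 to compound 3 (the limit leaves the size open), within the scatter.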

Compound 3, half-maximal cytotoxic concentration: > 100000 nM
Compound 3: only a limit was reported; the forecaster's own chance of this, stated with the estimate: 65%; the middle value lies on the limit itself.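

In this assay compound 1 and compound 3 both stand at a limit, so no step between them can be read: the limit of > 100000 nM in this assay, at which 2 of the 3 values shown sit.

The compounds shown leave open whether pyridin-3-yl in place of 4-fluorophenyl changes the tolerated concentration at all.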